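The compounds below may be only part of what the source reports. "The series", "measured", "known", "first", "only" and "open" are said of these compounds alone.

Measured compounds in an assay on isolated protein for inhibition of DNA topoisomerase 1 (Homo sapiens), with a stated time of 30 min, tested at 100 uM; a higher number here means a stronger effect of the compound at the concentration tested, a lower number a weaker effect:
- compound 1 `Oc1cccc(-c2cc(-c3cccnc3)nc(-c3ccccc3Cl)c2)c1`: 0%
- compound 2 `Oc1cccc(-c2cc(-c3ccc(Cl)cc3)nc(-c3cccnc3)c2)c1`: 2.8%
- compound 3 `Oc1ccc(-c2cc(-c3cccnc3)nc(-c3ccccc3Cl)c2)cc1`: 0.9%

Compound 1 sits at the bottom of the three numbers, but the gaps to the others are small. The step of a number 2.8 percentage points higher from compound 1 to compound 2 (within the scatter) and the step of a number 0.9 percentage points higher from compound 1 to compound 3 (within the scatter) are both within the scatter, so all three compounds are, in effect, inactive at the tested concentration in this assay.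

Compound 4 `Oc1cccc(-c2cc(-c3ccsc3)nc(-c3ccccc3Cl)c2)c1` is not yet measured. Its change from compound 1 is thiophen-3-yl in place of pyridin-3-yl on an aromatic carbon. Neither measured step touches this position: the step to compound 2 alters the 2-chlorophenyl group, the step to compound 3 the 3-hydroxyphenyl group, and both left the read-out flat. Among the measured compounds shown here, there is therefore no measured step that bears directly on the exchange at this position, and nothing suggests that any single change lifts the read-out beyond the scatter.

The step of a number 2 percentage points higher from compound 1 to compound 4 (within the scatter) is therefore expected to stay within the scatter. For compound 4 the estimate is 2% in this assay, with a range from 0% to 12%.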

Compound 4, a percentage reported as inhibition, at one concentration (the size of the read-out at that concentration, not a potency): 0%
Compound 4: middle estimate off by 2 percentage points, on the high side; the range from low to high includes it.
By their numbers in this assay, from the lowest: compounds 1, 4, 3 and 2 (each within the scatter of the next).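

Thiophen-3-yl in place of pyridin-3-yl, at the aromatic carbon next to the ring nitrogen, gives in this assay no change at the digits printed from compound 1 to compound 4 (within the scatter), the first measured step at this position. The flat read-out therefore now extends to this position as well as the two aryl groups changed earlier: exchanging a six-membered aromatic ring carrying nitrogen for a five-membered one carrying sulfur does not lift the number beyond the scatter. No available evidence bears on why this exchange leaves the read-out flat.

Open, going by these compounds, is whether a non-aromatic group at this position, such as a primary amine, a carboxylic acid or a longer alkyl chain, would move the read-out beyond the scatter. With all four compounds inactive at the tested concentration, the series offers no active reference against which to rank any of these positions.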